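The compounds below may be only part of what the source reports. "The series", "measured", "known", "first", "only" and "open" are said of these compounds alone.

Compound 2, with the structure `COCc1ccccc1C1Cc2nccn2C1`, is measured in a functional assay on CHO cells for agonist activity at Alpha-1A adrenergic receptor (Homo sapiens), read by FLIPR and calcium flux (on this read-out higher numbers stand for an effect only at larger amounts of compound and lower numbers for an effect already at smaller amounts), and gives 82 nM. Among the compounds with a single number in this assay, it stands at the lowest point: the nearest neighbour is compound 3, `Clc1cccc(C2CCc3nc[nH]c3C2)c1`, which in this assay gives 514 nM, a gap beyond the usual scatter. Compound 1, `COCc1ccccc1C1CCc2nc[nH]c2C1`, carries the same methoxymethyl group as compound 2 on a different core. Run twice in this assay, compound 1 gives 76 nM; 48 nM (2 entries); these repeated entries the several entries of compound 1 in this assay, 76 nM; 48 nM (2 entries) show how far two runs of the same compound can drift apart.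

Compound 4, `FC(F)Oc1ccccc1C1Cc2nccn2C1`, has not yet been measured. It keeps the core of compound 2 and changes one group on the aromatic ring: difluoromethoxy in place of methoxymethyl on an aromatic carbon. No pair of measured compounds here differs in this way, so the size of the step cannot be read from the numbers shown; the two groups resemble each other in count of heavy atoms and in hydrogen-bond acceptors, and a step within or only slightly beyond the scatter is expected, toward a somewhat higher number if anything.

Compound 4 is therefore estimated to give 120 nM in this assay, in a range from 40 nM to 400 nM, meaning an expected step of a 1.5-fold higher number from compound 2 to compound 4 (0.17 log units; within the scatter).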

Compound 4, half-maximal effective concentration: 11 nM
Beside the measured number, compound 4's estimate is 11-fold (1.04 log units) above it, outside the stated range (below it).
By their numbers in this assay, from the lowest: compound 4; then compound 2; then compound 3.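

In this assay, the exchange of methoxymethyl for difluoromethoxy on this aromatic carbon, ortho to a group of 8 heavy atoms, gives a 7.5-fold lower number from compound 2 to compound 4 (0.87 log units; beyond the scatter). Among these compounds, no earlier pair differed at this position alone, so this is the first evidence that the group placed here can shift the number clearly, even though the two groups have the same count of hydrogen-bond donors and the same count of hydrogen-bond acceptors. Repeated runs of a single compound offer a sense of how far numbers can drift without any change in structure, and this step is printed as beyond the usual scatter, as a look at those repeats helps to show: the several entries of compound 1 in this assay, 76 nM; 48 nM (2 entries)

The compounds shown leave open whether the same exchange would move the number in the same direction on the core of compound 1, and how a plain methoxy, a trifluoromethoxy or an amine would read at this place. They also cannot tell which of the differences between methoxymethyl and difluoromethoxy lies behind the step, since a single pair cannot separate them.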